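The source may hold more compounds than are shown below. What is called first, only, known or untested is meant among the compounds shown, and "the series" means these compounds.

In a functional assay on MCF7 cells (Homo sapiens) for inhibition, read by sulforhodamine B assay, with a stated time of 48 h (on this read-out lower numbers stand for stronger inhibition of growth and higher numbers for weaker inhibition of growth), compound 1 `Ic1ccc(Cn2cc(CCCOc3cccc4cccnc34)nn2)cc1` gives 25 ug/mL. It stands level with compound 2 `Brc1ccc(Cn2cc(CCCOc3cccc4cccnc34)nn2)cc1` at 28 ug/mL, and these two form the high end of the three numbers, while compound 3 `Clc1ccc(Br)cc1Cn1cc(CCCOc2cccc3cccnc23)nn1` gives 9.6 ug/mL. Compound 4 `c1ccc(Cn2cc(CCCOc3cccc4cccnc34)nn2)cc1` differs from compound 1 by hydrogen in place of iodo on an aromatic carbon. The closest evidence is a 1.1-fold higher number from compound 1 to compound 2 (0.05 log units; within the scatter), a swap of one halogen for another. Among the measured compounds shown here, the larger steps, a 2.6-fold lower number from compound 1 to compound 3 (0.42 log units; beyond the scatter) and a 2.9-fold lower number from compound 2 to compound 3 (0.46 log units; beyond the scatter), both introduce 5-bromo-2-chlorophenyl, and no measured compound lacks a halogen. A change within the scatter is therefore expected, if anything towards a higher number. The expected change is a 1.2-fold higher number from compound 1 to compound 4 (0.08 log units; within the scatter). Compound 4 is estimated at 30 ug/mL, with an expected range from 14 ug/mL to 60 ug/mL.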

Compound 4, concentration for 50% growth inhibition: 12.7 ug/mL
For compound 4 the middle estimate is 2.4-fold (0.37 log units) above the measured one; the whole stated range lies above it.
By their numbers in this assay, from the lowest: compounds 3, 4, 1 and 2 (each within the scatter of the next, the first and the last beyond it).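

Compound 4, with its plain phenyl, shows that a halogen on this aromatic carbon is not needed for growth inhibition: hydrogen in place of bromo gives a 2.2-fold lower number from compound 2 to compound 4 (0.34 log units; beyond the scatter) and hydrogen in place of iodo gives a 2.0-fold lower number from compound 1 to compound 4 (0.29 log units; within the scatter) on the same position. Replacing the 5-bromo-2-chlorophenyl with phenyl gives a 1.3-fold higher number from compound 3 to compound 4 (0.12 log units; within the scatter) in this series, so the two-halogen ring holds no clear edge over the bare one. No evidence bearing on the cause of these differences is available.

The compounds shown leave open how an amine or a methoxy group on this aromatic carbon would read. They also leave open what a longer chain in the core of compound 4 would do.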